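Replacing a Nitrophenyl Ether with Naphthyl in a Triazole Series

This account rests on a few compounds, and the source may have more. Where it says the series, first, only, none or still open, it means among the compounds named here.

Three compounds share one core, an aryl triazole carrying a methanesulfonamide and a phenoxy group. Compound 1 `Cc1cc(OCc2cn(-c3ccc(NS(C)(=O)=O)c(Oc4ccccc4)c3)nn2)ccc1Cl` is the only one with a result: in a functional assay on HeLa cells (Homo sapiens) for inhibition, read by MTT assay, with a stated time of 48 h (a lower number here means a stronger inhibitor, a higher number a weaker inhibitor), compound 1 gives 7900 nM, which places it among weak inhibitors. Compound 2 `CS(=O)(=O)Nc1ccc(-n2cc(COc3ccc([N+](=O)[O-])cc3)nn2)cc1Oc1ccccc1` was put into this assay, but for compound 2 the entry reads "not determined" (no result reported), so its standing cannot be set against compound 1. Compound 3 `CS(=O)(=O)Nc1ccc(-n2cc(COc3ccc4ccccc4c3)nn2)cc1Oc1ccccc1` is the next member and has not yet been measured. The difference between compound 2 and compound 3 is naphthalen-2-yl in place of 4-nitrophenyl on an oxygen on a saturated carbon. Since compound 2 carries no number, the step in this assay from compound 2 to compound 3 cannot be sized from measured values, and neither a direction nor a change beyond the scatter can be asserted. Taking compound 1 as the only anchor, compound 3 is expected to give about 5000 nM in this assay, within a range of 1500 nM to 20000 nM.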

Compound 3, half-maximal inhibitory concentration: 12800 nM
The estimate for compound 3 lay 2.6-fold (0.41 log units) below the measured number, and the stated range covers the measured number.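

In this assay, within the data shown here, the first readable step at this position is a 1.6-fold higher number from compound 1 to compound 3 (0.21 log units; within the scatter) with naphthalen-2-yl in place of 4-chloro-3-methylphenyl on the oxygen. The two-ring naphthalen-2-yl group and the single-ring 4-chloro-3-methylphenyl group therefore cannot be told apart in this measurement, and the shared core stays among weak inhibitors with either group. The step from 4-nitrophenyl cannot be read, and nothing available offers an explanation for the result.

The compounds shown leave open how 4-nitrophenyl compares with these two groups. They also leave open whether a group other than an aromatic ring on this oxygen, such as a longer chain ending in an amine or a carboxylic acid, would shift the number beyond the scatter.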